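Swapping trifluoromethyl for ethyl in compound 4

The source may report more compounds than this note shows. Statements on the series, on what has been measured and on what is new or still open speak of the compounds shown alone.

compound 1 `CCCCc1ccc2[nH]c(-c3ccc(CC)cc3)c(/C=N/NC(=O)c3ccncc3)c2c1`: 80 nM
compound 2 `CCCCc1ccc2[nH]c(-c3ccc(OC)cc3)c(/C=N/NC(=O)c3cccnc3)c2c1`: 35 nM
compound 3 `CCCCc1ccc2[nH]c(-c3ccc(C(F)(F)F)cc3)c(/C=N/NC(=O)c3cccnc3)c2c1`: 97 nM

In a functional assay on MDA-MB-231 cells (Homo sapiens) for antiproliferative activity, with a stated time of 4 days (a lower number here means a stronger inhibitor, a higher number a weaker inhibitor), compound 3 lies within the scatter of compound 1 but sits clearly above compound 2. Compound 4 `CCCCc1ccc2[nH]c(-c3ccc(CC)cc3)c(/C=N/NC(=O)c3cccnc3)c2c1` changes one group of compound 3, with ethyl in place of trifluoromethyl on an aromatic carbon. Among the measured compounds shown here, the only measured step at that place, a 2.8-fold higher number from compound 2 to compound 3 (0.44 log units; beyond the scatter), was modest and brought in trifluoromethyl in place of methoxy. For the measured compounds named here, the one measured ethyl compound, compound 1, gives 80 nM. Only a small move toward a lower number is therefore expected, namely a 1.5-fold lower number from compound 3 to compound 4 (0.17 log units; within the scatter). Compound 4 is estimated at 65 nM, with an expected range of 30 nM to 130 nM.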

Compound 4, half-maximal inhibitory concentration: 53 nM
Compound 4: middle estimate off by 1.2-fold (0.09 log units), on the high side; the range from low to high includes it.
By their numbers in this assay, from the lowest: compounds 2, 4, 1 and 3 (each within the scatter of the next, the first and the last beyond it).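

In this assay, ethyl at this place stays within the scatter of both other groups: the data give a 1.8-fold lower number from compound 3 to compound 4 (0.26 log units; within the scatter) and a 1.5-fold higher number from compound 2 to compound 4 (0.18 log units; within the scatter) even though a 2.8-fold higher number from compound 2 to compound 3 (0.44 log units; beyond the scatter) lies beyond it. Among the compounds shown here, the first direct comparison of the two pyridines, a 1.5-fold lower number from compound 1 to compound 4 (0.18 log units; within the scatter) for pyridin-3-yl in place of pyridin-4-yl, does not separate them either. No measurement shown explains these numbers. The compounds shown leave open whether an amine, a carboxylic acid or a chain longer than ethyl at this place would give a number clearly apart from these.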